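Swapping the amide aryl group in a chromene series

The source may hold more compounds than are shown below. What is called first, only, known or untested is meant among the compounds shown, and "the series" means these compounds.

Three compounds share one core, here carried by compound 2 with structure `CCOC(=O)C1=Cc2ccccc2OC1(OCc1cn(CC(=O)Nc2ccc(OC)cc2)nn1)C(F)(F)F`. In a functional assay on MCF7 cells (Homo sapiens) for inhibition, read by MTT assay, with a stated time of 24 h (on this read-out higher numbers stand for weaker inhibition and lower numbers for stronger inhibition), compound 2 gives 28100 nM. This is the highest of the two plain numbers shown, though compound 3, with structure `CCOC(=O)C1=Cc2ccccc2OC1(OCc1cc(-c2cccc(C(F)(F)F)c2)no1)C(F)(F)F`, gives 22100 nM, which lies within the scatter of compound 2. Compound 1, with structure `CCOC(=O)C1=Cc2ccccc2OC1(OCc1cc(-c2ccc(F)cc2F)no1)C(F)(F)F`, is reported in this assay only as a limit, > 150000 nM.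

Going by the values given here, the one measured step, an at least 6.7-fold lower number from compound 1 to compound 3 (0.83 log units; beyond the scatter), concerns a change on an aromatic carbon and tells how the number moved there. The step from compound 2 to compound 4, whose structure is `CCOC(=O)C1=Cc2ccccc2OC1(OCc1cn(CC(=O)Nc2cccc(F)c2)nn1)C(F)(F)F`, is of another kind: 3-fluorophenyl in place of 4-methoxyphenyl on an amide-type nitrogen. Among the compounds with values here, no measured step touches this amide-type nitrogen, so nothing in the data shows how such a swap moves the number; the only guide is that compound 2 and compound 3 sit close together despite their differing side groups.

With no evidence pointing in either direction, compound 4 is expected to change little from compound 2, an expected step of a 1.0-fold lower number from compound 2 to compound 4 (0.00 log units; within the scatter) in this assay. The estimate for compound 4 is therefore 28000 nM, expected to fall between 9000 nM and 90000 nM.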

Compound 4, half-maximal inhibitory concentration: > 150000 nM
Compound 4 ended at the assay's limit; the forecaster's own chance of this, stated with the estimate: 15%; middle value at least 5.3-fold (0.72 log units) away from the limit.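

Going by these compounds alone, this is the first step measured at the amide-type nitrogen, and in this assay the change of aryl group there is not neutral: it gives an at least 5.3-fold higher number from compound 2 to compound 4 (0.72 log units; beyond the scatter). Both groups are single six-membered aromatic rings of carbon, so the pair shows that replacing 4-methoxyphenyl with 3-fluorophenyl on this nitrogen is enough to move the read-out well beyond the scatter, although this rests on one pair of compounds. The true size of the step remains unknown because the result for compound 4 is a limit and not a number, so the printed step gives only the smallest change consistent with it: the limit of > 150000 nM in this assay, at which 2 of the 4 values shown sit.

The compounds shown do not separate the loss of the 4-methoxyphenyl group from the arrival of the 3-fluorophenyl group, a question that plain phenyl, 4-fluorophenyl or 3-methoxyphenyl on the same nitrogen would address. They also leave open how this assay would respond to a different kind of group at this position, such as benzyl, cyclohexyl or a 4-aminophenyl ring.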